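This account rests on a few compounds, and the source may have more. Where it says the series, first, only, none or still open, it means among the compounds named here.

Compound 2 `COc1cc(-c2nn(-c3cccc(NC(=O)Nc4ccc(Cl)c(C(F)(F)F)c4)c3)cc2-c2ccncc2)ccc1Cl` holds the lowest of the two numbers in a functional assay on SW-620 cells (Homo sapiens) for inhibition, read by sulforhodamine B assay, with a stated time of 48 h (a higher number here means a weaker inhibitor of growth, a lower number a stronger inhibitor of growth), where compound 2 gives 1290 nM. Its nearest neighbour is compound 1 `COc1cc(-c2nn(-c3cccc(NC(=O)c4cccc(C(F)(F)F)c4)c3)cc2-c2ccncc2)ccc1Cl`, which in this assay gives 2310 nM; the step of a 1.8-fold lower number from compound 1 to compound 2 (0.25 log units; within the scatter) stays within the scatter. Compound 3 `COc1cc(-c2nn(-c3cccc(NC(=O)c4ccccc4)c3)cc2-c2ccncc2)ccc1Cl` has not yet been measured. Its change from compound 2 is phenyl in place of (4-chloro-3-(trifluoromethyl)phenyl)amino on a carbonyl carbon. Going by the values given here, only one measured step touches this position, namely a 1.8-fold lower number from compound 1 to compound 2 (0.25 log units; within the scatter), and it showed no movement beyond the scatter. Among the compounds with values here, neither measured compound carries a plain phenyl here, since compound 1 still keeps a trifluoromethyl on its ring, so the removal of both substituents together has no measured counterpart. The author therefore expects a weakening in this assay, a step of a 3.9-fold higher number from compound 2 to compound 3 (0.59 log units; beyond the scatter), somewhat beyond the scatter but uncertain in size. Compound 3 is estimated at 5000 nM, with a range from 1800 nM to 14000 nM.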

Compound 3, concentration for 50% growth inhibition: 551 nM
Compound 3: the middle estimate sits 9.1-fold (0.96 log units) above what was measured; the measured number lies below the stated range.
By their numbers in this assay, from the lowest: compound 3; then compounds 2 and 1 (each within the scatter of the next).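

In this assay, the step at this position now moves beyond the scatter: a 2.3-fold lower number from compound 2 to compound 3 (0.37 log units; beyond the scatter), with phenyl replacing (4-chloro-3-(trifluoromethyl)phenyl)amino on the carbonyl carbon. Hydrogen in place of trifluoromethyl on the aromatic carbon gives a 4.2-fold lower number from compound 1 to compound 3 (0.62 log units; beyond the scatter), so the trifluoromethyl is not needed for growth inhibition in this series, and compound 3, with the bare phenyl, holds the lowest number of the three. Nothing available explains why the bare ring does better.

As far as these compounds go, what remains open is whether the gain in compound 3 would survive a plain phenylamino on the carbonyl carbon, which would separate the ring substituents from the added nitrogen. From the compounds shown here alone, it is also open whether a small group on the phenyl ring, such as a fluorine, a methoxy or an amine, would lower the number further.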